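This account rests on a few compounds, and the source may have more. Where it says the series, first, only, none or still open, it means among the compounds named here.

Measured so far:
- Compound 1, `Cc1cccc(NC(=O)CN2CCC(c3ccc(O)cc3)CC2)c1`: 60%
- Compound 2, `O=C(NCN1CCC(c2cccc[n+]2[O-])CC1)c1cc(Cl)cc(Cl)c1`: 64%
- Compound 3, `O=C(CN1CCC(c2cccc[n+]2[O-])CC1)Nc1cccc(F)c1`: 70%

All three numbers come from a functional assay on HEK293 cells for agonist activity at D(4) dopamine receptor (Homo sapiens), read by FLIPR; on this read-out higher numbers stand for larger maximal responses and lower numbers for smaller maximal responses. Compound 1 sits at the low end of the three, yet its gap to compound 2 and its gap to compound 3 both fall within the usual scatter, so the three compounds cannot be separated on these numbers.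

Compound 4, `COc1ccccc1C1CCN(CC(=O)Nc2cccc(C)c2)CC1`, is the next entry for this assay. It differs from compound 1 in one place: 2-methoxyphenyl in place of 4-hydroxyphenyl on a saturated ring carbon. The change removes the hydrogen-bond donor of the 4-hydroxyphenyl group and shifts the oxygen within the ring substituent. Among the measured compounds shown here, no measured pair shows a comparable step, so the size of the effect is unknown; the expectation is a step of no change at the digits printed from compound 1 to compound 4 (within the scatter), that is, none beyond the scatter. Compound 4 is therefore estimated at 60%, with a range from 40% to 80%.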

Compound 4, largest response reached (reported as efficacy), in percent of the reference or control that the assay uses: 43%
Compound 4: the middle estimate sits 17 percentage points above what was measured; measured number inside the range.
By their numbers in this assay, from the lowest: compound 4; then compounds 1, 2 and 3 (each within the scatter of the next).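

In this assay, among the compounds shown here, the swap of 2-methoxyphenyl for 4-hydroxyphenyl on the saturated ring carbon gives a number 17 percentage points lower from compound 1 to compound 4 (beyond the scatter) and is the first single-place step. This position is therefore not indifferent to the aryl group it carries, although the step is modest. Nothing available explains the step.

The step combines two changes, methyl on the oxygen and a new oxygen position on the aromatic ring, and the compounds shown do not separate them. Open, going by these compounds, is how 4-methoxyphenyl or 2-hydroxyphenyl would read at this position.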